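Sulfonyl aryl change on the quinoline-free core of compound 2

This account rests on a few compounds, and the source may have more. Where it says the series, first, only, none or still open, it means among the compounds named here.

Measured compounds:
compound 1 `Cc1ccc(S(=O)(=O)c2cnc3ccc(Cl)cc3c2N2CCC(C)CC2)cc1F`, 68%
compound 2 `COc1ccc(S(=O)(=O)c2cnc3c(F)cccc3c2N2CCC(C)CC2)cc1`, 67%
compound 3 `CC1CCN(c2c(S(=O)(=O)c3ccccc3)cnc3cc(Cl)ccc23)CC1`, 93%

In an assay on isolated protein for displacement of a labelled ligand from metabotropic glutamate receptor 5 (Homo sapiens), with a stated time of 60 min, tested at 1 uM (on this read-out lower numbers stand for less inhibition and higher numbers for more inhibition at the one concentration tested (going by the name of the read-out)), compound 2 gives 67%. Compound 1 and compound 2 lie within the scatter of each other; compound 3 sits above compound 2 by a margin beyond the scatter, though compound 3 differs in more than one place, so its gap to compound 2 is only what the two values show. Compound 4 `CC1CCN(c2c(S(=O)(=O)c3cccc(F)c3)cnc3c(F)cccc23)CC1` has not yet been measured. It differs from compound 2 in one place: 3-fluorophenyl in place of 4-methoxyphenyl on a sulfonyl sulfur. Among the compounds with values here, no single-place step among the measured compounds covers this change, so no measured guide exists. The change is expected to give a small upward step, a number 8 percentage points higher from compound 2 to compound 4 (within the scatter), possibly within the scatter. Compound 4 is estimated at 75%, range 55% to 90%.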

Compound 4, a percentage reported as inhibition, at one concentration (the size of the read-out at that concentration, not a potency): 62%
Compound 4: middle estimate off by 13 percentage points, on the high side, and the stated range covers the measured number.
By their numbers in this assay, from the lowest: compounds 4, 2 and 1 (each within the scatter of the next); then compound 3.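

Measured by this assay with the shared core held fixed, 3-fluorophenyl in place of 4-methoxyphenyl on a sulfonyl sulfur gives a number 5 percentage points lower from compound 2 to compound 4 (within the scatter). Within the data shown here, this is the first single-place reading at this position, and it shows that these two aryl groups are not separated in this read-out, even though only 4-methoxyphenyl counts a hydrogen-bond acceptor. No supporting measurement bears on this result. Still open, from the compounds shown here alone, is how the position responds to an amine or a carboxylic acid in place of the aryl group on a sulfonyl sulfur. Also open, going by these compounds, is whether this exchange gives a similar step on a different core.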